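Placing a Hydroxy Group on Compound 2

A few compounds are considered here, and "the series" means these few. Any claim that something is new, unique, unknown or untested is made for them only; others in the source may bear on it.

In an ADME assay on the whole organism (strain CD-1) for metabolic stability, with Mus musculus as the target, at a dose of 50 mg/kg by the oral route (on this read-out higher numbers stand for a longer-lived compound and lower numbers for a shorter-lived compound), compound 1 (`O=C(NC[C@@H]1CC(Br)=NO1)[C@@H]1C[C@@H](c2ccc(O)cc2)CN1C(=O)OCc1cnc2ccccc2c1`) gives 0.25 h and compound 2 (`O=C(NC[C@@H]1CC(Br)=NO1)[C@@H]1CCCN1C(=O)OCc1cnc2ccccc2c1`) gives 0.25 h. Compound 2 therefore stands level with compound 1, its nearest and only measured neighbour.

Compound 3 (`O=C(NC[C@@H]1CC(Br)=NO1)[C@@H]1C[C@@H](O)CN1C(=O)OCc1cnc2ccccc2c1`) has not yet been measured. It differs from compound 2 by a single change: hydroxy in place of hydrogen on a saturated ring carbon. That is hydroxy in place of hydrogen on a saturated ring carbon, two ring bonds from the ring nitrogen.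

Among the compounds with values here, one measured step bears on this change, the replacement of 4-hydroxyphenyl by hydrogen on a saturated ring carbon in going from compound 1 to compound 2: no change at the digits printed from compound 1 to compound 2 (within the scatter). This step did not move the half-life beyond the scatter, although the group removed was much larger than hydroxy. Still, it is a single comparison, and hydroxy alone has not been tested on this core. No shift beyond the scatter is therefore expected, in either direction, and the estimated change is no change at the digits printed from compound 2 to compound 3 (within the scatter). Compound 3 is expected at 0.25 h, with an estimated range of 0.14 h to 0.5 h.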

Compound 3, half-life: 0.25 h
For compound 3 middle estimate and measured number coincide at the digits printed; the measured number falls inside the stated range.
By their numbers in this assay, from the lowest: compounds 1, 2 and 3 (each within the scatter of the next).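

In this assay, the step for hydroxy in place of hydrogen on a saturated ring carbon, two ring bonds from the ring nitrogen, reads no change at the digits printed from compound 2 to compound 3 (within the scatter), which gives this position a direct test with a single oxygen-bearing group rather than only with the much larger 4-hydroxyphenyl. The two substituted compounds can now also be set against each other, and the step for hydroxy in place of 4-hydroxyphenyl reads no change at the digits printed from compound 1 to compound 3 (within the scatter), so hydrogen, hydroxy and 4-hydroxyphenyl on this carbon all lie within the scatter of one another on the shared core. No independent measurement is available to explain this flat result.

The compounds shown leave open whether any group on this carbon can move the half-life beyond the scatter, since an amine, a carboxylic acid and a longer alkyl chain do not appear among them. They also leave open whether a change elsewhere on the shared core, such as another group in place of the bromine, would shift the half-life where these three substituents on the saturated ring carbon do not.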